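This account rests on a few compounds, and the source may have more. Where it says the series, first, only, none or still open, it means among the compounds named here.

- Compound 1 `C=C(Br)C(=O)Nc1ccc(/C=C/C(=O)c2ccc(I)cc2)cc1`: 2800 nM
- Compound 2 `C=C(Br)C(=O)Nc1ccc(/C=C/C(=O)c2ccc(OCC)cc2)cc1`: 610 nM
- Compound 3 `C=C(Br)C(=O)Nc1ccc(/C=C/C(=O)c2cccc3ccccc23)cc1`: 2100 nM
- Compound 4 `C=C(Br)C(=O)Nc1ccc(/C=C/C(=O)c2cccs2)cc1`: not yet measured

All three measured compounds were tested in a functional assay on MOLT-4 cells (Homo sapiens) for antiproliferative activity, with a stated time of 48 h; on this read-out lower numbers stand for stronger inhibition and higher numbers for weaker inhibition. There compound 1 gives 2800 nM, and compound 3, at 2100 nM, lies within the usual scatter of it. Compound 2 stands clearly apart from both at 610 nM.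

Compound 4 keeps the core of compound 1 and changes a single group: thiophen-2-yl in place of 4-iodophenyl on a carbonyl carbon. It carries thiophen-2-yl in place of 4-iodophenyl on a carbonyl carbon.

Among the measured compounds shown here, no measured compound carries thiophen-2-yl, so the evidence is indirect. For the measured compounds named here, one measured step bears on the change: a 4.6-fold lower number from compound 1 to compound 2 (0.66 log units; beyond the scatter), with ethoxy in place of iodo on an aromatic carbon. That step is modest but beyond the scatter, and it shows that losing the iodo need not cost activity. Compound 3 also has a different group on the carbonyl carbon, yet its value of 2100 nM stays within the scatter of compound 1.

Together these suggest a small shift towards a lower number in this assay, probably not beyond the scatter. The estimated change is a 1.9-fold lower number from compound 1 to compound 4 (0.27 log units; within the scatter). For compound 4 the expected value is 1500 nM, with an estimated range of 500 nM to 3800 nM.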

Compound 4, half-maximal inhibitory concentration: 550 nM
The estimate for compound 4 lay 2.7-fold (0.44 log units) above the measured number, and the stated range covers the measured number.
By their numbers in this assay, from the lowest: compounds 4 and 2 (each within the scatter of the next); then compounds 3 and 1 (each within the scatter of the next).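

In this assay, thiophen-2-yl in place of 4-iodophenyl on the carbonyl carbon gives a 5.1-fold lower number from compound 1 to compound 4 (0.71 log units; beyond the scatter) and this modest step shows that the six-membered aromatic ring of carbon itself can be exchanged at this place without loss, whereas compound 2 had changed only the group carried on that ring. Compound 4 at 550 nM and compound 2 at 610 nM lie within the usual scatter of each other, so a five-membered aromatic ring with one hetero atom and a ring bearing ethoxy reach the same level here, even though compound 4 has fewer heavy atoms in this group than compound 1 has. No measurement shown here accounts for the gain seen with thiophen-2-yl.

The compounds shown leave open whether the sulfur atom matters, since neither furan-2-yl, with oxygen in its place, nor a plain unsubstituted phenyl ring stands among them. They also leave open how far thiophen-2-yl itself tolerates further groups, such as a methyl or an amine on the ring.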